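The compounds below may be only part of what the source reports. "The series", "measured", "known", "first", "only" and "open" are said of these compounds alone.

Three compounds share one core and differ only in the aromatic group that sits on a saturated chain carbon bound to an amine nitrogen in a ring. Compound 1 `COc1ccc2[nH]c3c(c2c1)CCNC31CCN(Cc2cc(Cl)ccc2[N+](=O)[O-])CC1` gives 7100 nM in an assay on FRT cells for positive allosteric modulation of Cystic fibrosis transmembrane conductance regulator variant N1303K (Homo sapiens), in the presence of a further agent that is not named here; a lower number here means that less compound is needed, a higher number that more compound is needed for the effect. Compound 2 `COc1ccc2[nH]c3c(c2c1)CCNC31CCN(Cc2ccc(Br)cc2F)CC1` gives 1600 nM in the same assay, and compound 3 `COc1ccc2[nH]c3c(c2c1)CCNC31CCN(Cc2ccco2)CC1` gives 16400 nM, the highest number of the three. The steps leading to compound 3 are a 2.3-fold higher number from compound 1 to compound 3 (0.36 log units; beyond the scatter) and a 10-fold higher number from compound 2 to compound 3 (1.01 log units; beyond the scatter); between the two six-membered rings the step was a 4.4-fold lower number from compound 1 to compound 2 (0.65 log units; beyond the scatter). Compound 4 `COc1ccc2[nH]c3c(c2c1)CCNC31CCN(Cc2ccccn2)CC1` has not yet been measured. It differs from compound 3 by pyridin-2-yl in place of furan-2-yl on a saturated chain carbon bound to an amine nitrogen in a ring. Both measured steps that end in furan-2-yl at this position moved to a higher number, so a six-membered ring here is expected to bring the number down from compound 3, although both measured six-membered rings carry halogens while pyridin-2-yl carries none, which keeps the expectation modest. The step from compound 3 to compound 4 is therefore expected to be a 1.8-fold lower number from compound 3 to compound 4 (0.26 log units; within the scatter). Compound 4 is estimated at 9000 nM, with a range from 3000 nM to 25000 nM.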

Compound 4, half-maximal effective concentration: 11500 nM
For compound 4 the middle estimate is 1.3-fold (0.11 log units) below the measured one; low and high end bracket the measured number.
By their numbers in this assay, from the lowest: compound 2; then compounds 1, 4 and 3 (each within the scatter of the next, the first and the last beyond it).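

Replacing furan-2-yl with pyridin-2-yl changes the ring size on this saturated chain carbon, yet the result stays within the scatter (a 1.4-fold lower number from compound 3 to compound 4 (0.15 log units; within the scatter)), so a six-membered aromatic ring alone does not reproduce the low number of compound 2. That gap remains beyond the scatter (a 7.2-fold higher number from compound 2 to compound 4 (0.86 log units; beyond the scatter)), while pyridin-2-yl cannot be separated from 5-chloro-2-nitrophenyl (a 1.6-fold higher number from compound 1 to compound 4 (0.21 log units; within the scatter)), and among these compounds only 4-bromo-2-fluorophenyl stands apart from pyridin-2-yl. Nothing available here explains these differences.

Still open, from the compounds shown here alone, is how an unsubstituted phenyl would compare with pyridin-2-yl on this carbon. Also open, going by these compounds, is whether the bromine or the fluorine carries the difference seen for compound 2, which 4-bromophenyl and 2-fluorophenyl groups could separate.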